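This account rests on a few compounds, and the source may have more. Where it says the series, first, only, none or still open, it means among the compounds named here.

Measured compounds:
Compound 1, `Cc1ccc(-n2nc(-c3ccc4ccccc4c3)nc2N2C(=O)C(C)OC23C=CC(=O)C=C3)cc1`: in a functional assay on HeLa cells (Homo sapiens) for antiproliferative activity, with a stated time of 5 days (on this read-out higher numbers stand for weaker inhibition and lower numbers for stronger inhibition), compound 1 gives 530 nM.
Compound 2, `O=C1C=CC2(C=C1)OCC(=O)N2c1nc(-c2ccc3ccccc3c2)nn1-c1ccc2ccccc2c1`: in this assay compound 2 gives 210 nM.
Compound 3, `O=C1C=CC2(C=C1)OCC(=O)N2c1nc(-c2ccc(F)c3ccccc23)nn1-c1ccccc1`: in this assay compound 3 gives 200 nM.

Compound 3 sits at the low end of these three numbers. Its number and that of compound 2 lie within the usual scatter of each other, so nothing separates the two; only compound 1 stands apart, with a number beyond the scatter above that of compound 3.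

Compound 4, `O=C1C=CC2(C=C1)OCC(=O)N2c1nc(-c2ccc3ncccc3c2)nn1-c1ccccc1`, has not been measured in this assay. It differs from compound 3 in one place: quinolin-6-yl in place of 4-fluoronaphthalen-1-yl on an aromatic carbon. Within the data shown here, no pair of measured compounds differs in exactly this way, so no measured step tells how large the change should be. Compounds 1 and 2 carry other groups at this place and other groups elsewhere, so their numbers say only that the region tolerates several aromatic groups without leaving the range seen here.

The step from compound 3 to compound 4 is estimated to be small, a 1.8-fold higher number from compound 3 to compound 4 (0.24 log units; within the scatter), at most a modest drift toward a higher number, likely within the scatter. For compound 4 the expected value in this assay is 350 nM, with a range from 120 nM to 1200 nM.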

Compound 4, half-maximal inhibitory concentration: 110 nM
Compound 4: middle estimate off by 3.2-fold (0.50 log units), on the high side; measured number below the stated range.
By their numbers in this assay, from the lowest: compounds 4, 3 and 2 (each within the scatter of the next); then compound 1.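

In this assay, among these compounds, the step at this aromatic carbon, a 1.8-fold lower number from compound 3 to compound 4 (0.26 log units; within the scatter), is the first single-place comparison, and it stays within the usual scatter. Quinolin-6-yl, which brings a ring nitrogen and a hydrogen-bond acceptor, therefore cannot be told apart from 4-fluoronaphthalen-1-yl, which has neither, so at this place the two-ring aromatic groups compared so far read alike. Nothing shown here gives a reason for this result.

The step swaps the whole group, so the loss of the fluorine and the arrival of the ring nitrogen cannot be judged separately. From the compounds shown here alone, it also remains open whether the number would stay in this range with a plain phenyl group, or with a group lacking an aromatic ring, such as an amine, a carboxylic acid or a longer chain.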